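The compounds below may be only part of what the source reports. "The series", "measured", "known", "first", "only" and "open" are said of these compounds alone.

Compound 3 `CC(C)c1onc(-c2c(Cl)cccc2Cl)c1COc1ccc(-c2nc3ccc(C(=O)O)cc3n2C2CC2)cc1` gives 3200 nM in an assay on HEK-293T cells for antagonist activity at vitamin D3 receptor (Homo sapiens), read by a luciferase reporter, with a stated time of 24 h (a higher number here means a weaker inhibitor, a lower number a stronger inhibitor), the second highest of the three numbers: compound 1 `CCC(CC)n1c(-c2ccc(OCc3c(-c4c(Cl)cccc4Cl)noc3C(C)C)cc2)nc2ccc(C(=O)O)cc21` gives 5690 nM, and compound 2 `CCCn1c(-c2ccc(OCc3c(-c4c(Cl)cccc4Cl)noc3C(C)C)cc2)nc2ccc(C(=O)O)cc21` gives 1400 nM. Compound 4 `CC(C)c1onc(-c2c(Cl)cccc2Cl)c1COc1ccc(-c2nc3ccc(C(=O)O)cc3n2C2CCCCCC2)cc1` differs from compound 3 by cycloheptyl in place of cyclopropyl on an aromatic nitrogen. Among the measured compounds shown here, two measured steps bear on this change at the aromatic nitrogen: a 1.8-fold lower number from compound 1 to compound 3 (0.25 log units; within the scatter), and a 2.3-fold higher number from compound 2 to compound 3 (0.36 log units; beyond the scatter). The pentan-3-yl of compound 1 and the cyclopropyl of compound 3 thus lie within the scatter of each other, while the propyl of compound 2 gives a lower number. Cycloheptyl brings seven carbons to that nitrogen, closer in count to the pentan-3-yl of compound 1, so a step of about a 1.6-fold higher number from compound 3 to compound 4 (0.19 log units; within the scatter) is expected, at most modest and toward a higher number. Compound 4 is therefore estimated at 5000 nM, within 1800 nM to 14000 nM.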

Compound 4, half-maximal inhibitory concentration: 921 nM
Compound 4: the middle estimate sits 5.4-fold (0.73 log units) above what was measured; the measured number lies below the stated range.
By their numbers in this assay, from the lowest: compounds 4 and 2 (each within the scatter of the next); then compounds 3 and 1 (each within the scatter of the next).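

In this assay, the number of carbons on the aromatic nitrogen does not set the order: a 3.5-fold lower number from compound 3 to compound 4 (0.54 log units; beyond the scatter), and a 6.2-fold lower number from compound 1 to compound 4 (0.79 log units; beyond the scatter), so cycloheptyl does not track pentan-3-yl. Cycloheptyl instead stays within the scatter of the open propyl chain, a 1.5-fold lower number from compound 2 to compound 4 (0.18 log units; within the scatter), so a large ring and a short chain can give matching numbers at this position. Nothing shown explains this. From the compounds shown here alone, how ring size acts between cyclopropyl and cycloheptyl remains open, as does the reading for cyclopentyl or a chain ending in an amine on that nitrogen.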